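Adding a Second Chloro Group: What Compound 4 May Show

A few compounds are considered here, and "the series" means these few. Any claim that something is new, unique, unknown or untested is made for them only; others in the source may bear on it.

Three compounds with the same core have been measured:

compound 1 `O=C1NC(=S)/C(=C/c2cccc(Cl)c2)S1`: 11.2%
compound 2 `O=C1NC(=S)/C(=C/c2ccccc2Cl)S1`: 19.9%
compound 3 `O=C1NC(=S)/C(=C/c2ccc(Cl)c(Cl)c2)S1`: 19.4%

All three were tested in a functional assay on NCI-H292 cells (Homo sapiens) for cytotoxicity, read by MTT assay, with a stated time of 72 h, tested at 2.5 ug/mL; on this read-out higher numbers stand for more inhibition of growth at the one concentration tested and lower numbers for less inhibition of growth. Compound 1 and compound 2 have the same atoms joined differently; how their two cores differ is not broken down here. Compound 3 arises from compound 1 by one change, (chloro in place of hydrogen on an aromatic carbon), and this gave a number 8.2 percentage points higher from compound 1 to compound 3 (within the scatter). The values of compound 2 and compound 3 lie within the scatter of each other, so no order between them can be read.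

Compound 4 `O=C1NC(=S)/C(=C/c2c(Cl)cccc2Cl)S1` has not yet been measured. It arises from compound 2 by chloro in place of hydrogen on an aromatic carbon. Among the compounds with values here, this is the same kind of change as the one from compound 1 to compound 3, but the surroundings differ: in compound 3 the new chloro group sits ortho to a chloro group and para to a group of 8 heavy atoms, whereas in compound 4 it sits ortho to a group of 8 heavy atoms and meta to a chloro group. Because the earlier step, a number 8.2 percentage points higher from compound 1 to compound 3 (within the scatter), stayed within the scatter, a step of a number 5.1 percentage points higher from compound 2 to compound 4 (within the scatter) is expected from compound 2 to compound 4 in this assay, also within the scatter. Compound 4 is estimated to give 25%, most likely between 10% and 40%.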

Compound 4, percent growth inhibition at one concentration: 7.7%
For compound 4 the middle estimate is 17.3 percentage points above the measured one; the whole stated range lies above it.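

Placing a chloro group ortho to a group of 8 heavy atoms and meta to a chloro group gave a number 12.2 percentage points lower from compound 2 to compound 4 (beyond the scatter) in this assay. The same change therefore does not carry over unchanged from one core to the other, and its outcome in this series depends on the compound that receives it: the same change on two cores in this assay, a number 8.2 percentage points higher (within the scatter) from compound 1 to compound 3 and a number 12.2 percentage points lower (beyond the scatter) from compound 2 to compound 4, 20.4 percentage points apart, beyond the scatter of two such steps
Within the data shown here, this comparison rests on only two pairs of compounds, tested at a single concentration in one cell line, so it sets no general rule for chloro groups and does not show why the two steps differ.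

The compounds shown leave open whether the result for compound 4 belongs to the chloro group itself or would appear with any group at that place on the ring. A compound carrying a methyl group or a methoxy group there, with the rest of compound 4 kept the same, would help separate these two readings.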